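The source may hold more compounds than are shown below. What is called first, only, known or untested is meant among the compounds shown, and "the series" means these compounds.

Measured so far in a functional assay on HepG2 cells (Homo sapiens) for antiproliferative activity, read by MTT assay, with a stated time of 72 h; on this read-out higher numbers stand for weaker inhibition and lower numbers for stronger inhibition:
compound 1 `O=C1COc2ccc(-c3cccc(NS(=O)(=O)c4ccc(F)cc4)c3)cc2N1c1ccccc1`: 30300 nM
compound 2 `Cc1ccc(N2C(=O)COc3ccc(-c4cccc(NS(=O)(=O)c5ccc(F)cc5)c4)cc32)cc1`: > 40000 nM
compound 3 `COc1ccc(N2C(=O)COc3ccc(-c4cccc(NS(=O)(=O)c5ccc(F)cc5)c4)cc32)cc1`: 29800 nM

Compound 3 stands alongside compound 1: the step is a 1.0-fold lower number from compound 1 to compound 3 (0.01 log units; within the scatter), so the two cannot be told apart. For compound 2 the result is the limit of > 40000 nM in this assay, at which 1 of the 3 values shown sits, which is a limit and not a number. The steps on an aromatic carbon that involve compound 2, namely an at least 1.3-fold higher number from compound 1 to compound 2 (0.12 log units; that floor lies within the scatter) and an at least 1.3-fold lower number from compound 2 to compound 3 (0.12 log units; that floor lies within the scatter), are bounded by that limit and their floors sit within the scatter.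

Compound 4 `O=C1COc2ccc(-c3cccc(NS(=O)(=O)c4ccc(F)cc4)c3)cc2N1` differs from compound 3 by hydrogen in place of 4-methoxyphenyl on an amide-type nitrogen in a ring. Going by the values given here, no measured step removes the whole 4-methoxyphenyl; the three measured steps only exchange hydrogen, methyl or methoxy on an aromatic carbon of that group, and none of them moves beyond the scatter. As far as these compounds go, they give no direction for this assay , and a change of this size is untested, so the estimate for compound 4 stays close to the measured numbers, with a wide range and a real chance that only a limit is reported. For compound 4 the expected value is 30000 nM, with a range from 8000 nM to 100000 nM. The step this estimate implies is expected to be a 1.0-fold higher number from compound 3 to compound 4 (0.00 log units; within the scatter).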

Compound 4, half-maximal inhibitory concentration: > 40000 nM
Compound 4: no number, only a limit; the forecaster's own chance of this, stated with the estimate: 35%; at least 1.3-fold (0.12 log units) between middle value and limit.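

Replacing the whole 4-methoxyphenyl with hydrogen on the amide-type nitrogen in a ring is the first change shown that removes an entire aromatic ring rather than exchanging a group on one, and in this assay compound 4 gives > 40000 nM, which is a limit and not a number. The result gives an at least 1.3-fold higher number from compound 3 to compound 4 (0.12 log units; that floor lies within the scatter) and an at least 1.3-fold higher number from compound 1 to compound 4 (0.12 log units; that floor lies within the scatter); both are floors within the scatter, so they fix no size of loss, but nothing here points to stronger inhibition with hydrogen at this position. The step from compound 2 to compound 4 cannot be read, and the limit now covers both an aryl-bearing nitrogen and the unsubstituted one: the limit of > 40000 nM in this assay, at which 2 of the 4 values shown sit.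

How an ethyl, a benzyl or a longer chain ending in an amine would read on this nitrogen remains open, so the shown compounds do not settle whether any group here can move the number beyond the scatter. As far as these compounds go, the true values behind the limits of compound 2 and compound 4 also remain open.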